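Aryl for octyl on the triazole of compound 1

A few compounds are considered here, and "the series" means these few. Any claim that something is new, unique, unknown or untested is made for them only; others in the source may bear on it.

Compound 1 `CCCCCCCCn1cc(COC2(C(F)(F)F)Oc3ccccc3C=C2C(=O)OCC)nn1` carries an octyl chain on the triazole nitrogen of the shared core. In a functional assay on DU-145 cells (Homo sapiens) for inhibition, read by MTT assay, with a stated time of 24 h (on this read-out lower numbers stand for stronger inhibition and higher numbers for weaker inhibition), compound 1 gives only a limit, > 150000 nM, which is a limit of the assay rather than a measured number (the limit of > 150000 nM in this assay, at which 1 of the 3 values shown sits). Two other compounds on a related core have numbers: compound 2 `Cc1ccc(-c2cc(COC3(C(F)(F)F)Oc4ccccc4C=C3C(=O)O)on2)cc1` gives 41400 nM in this assay, and compound 3 `O=C(O)C1=Cc2ccccc2OC1(OCc1cc(-c2cccc(C(F)(F)F)c2)no1)C(F)(F)F` gives 155000 nM. For the measured compounds named here, the one measured step between them, a 3.7-fold higher number from compound 2 to compound 3 (0.57 log units; beyond the scatter), swaps one aryl group for another on an aromatic carbon and does not touch the change at hand.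

Compound 4 `CCOC(=O)C1=Cc2ccccc2OC1(OCc1cn(-c2ccc(C)cc2)nn1)C(F)(F)F` differs from compound 1 in one place (4-methylphenyl in place of octyl on an aromatic nitrogen). Going by the values given here, no measured step covers an octyl-to-aryl exchange on an aromatic nitrogen, and since compound 1 stands only at a limit, the direction of the step can be read only loosely from the numbers compound 2 and compound 3 show for aryl-bearing analogues. Compound 4 is therefore expected to land in a range where a number may or may not be reported, and the expected step of an at least 1.8-fold lower number from compound 1 to compound 4 (0.27 log units; that floor lies within the scatter) is stated as an estimate only. The estimate for compound 4 is 80000 nM, within 20000 nM to 300000 nM.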

Compound 4, half-maximal inhibitory concentration: 30200 nM
Compound 4: middle estimate off by 2.6-fold (0.42 log units), on the high side; the measured number falls inside the stated range.
By their numbers in this assay, from the lowest: compounds 4 and 2 (each within the scatter of the next); then compound 3.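

Up to this point, no measured step had touched this aromatic nitrogen: the one step available concerned an aryl exchange on an aromatic carbon of a related core. In this assay, the change of octyl to 4-methylphenyl gives an at least 4.9-fold lower number from compound 1 to compound 4 (0.69 log units; beyond the scatter), which shows that the group on this nitrogen matters to the read-out, with the aryl group on the side of the lower number. The size of this step is only a floor, and the figure for compound 1 is a limit of the assay: the limit of > 150000 nM in this assay, at which 1 of the 4 values shown sits.

With a single pair, the compounds shown do not separate the effect of exchanging a chain for a ring from that of the methyl group on the ring, so it remains open how an unsubstituted phenyl, a benzyl group or a shorter chain bearing an amine would read on this nitrogen. From the compounds shown here alone, it also remains open whether the aryl-for-octyl step would hold if the ethyl ester of the shared core gave way to an amide.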